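A Formyl Thiophene in Place of an Acetyl Thiophene

The compounds below may be only part of what the source reports. "The series", "measured", "known", "first", "only" and "open" are said of these compounds alone.

In a functional assay on MV4-11 cells (Homo sapiens) for inhibition, read by resazurin assay, with a stated time of 72 h (a higher number here means a weaker inhibitor of growth, a lower number a stronger inhibitor of growth), compound 1 (`O=C1NCCC12CCN(c1c(Cl)cncc1-c1ccsc1)CC2`) gives 190 nM, while compound 2 (`CC(=O)c1ccc(-c2cncc(Cl)c2N2CCC3(CCNC3=O)CC2)s1`) gives 1440 nM, the higher of the two numbers. Going by the values given here, the only measured step is a 7.6-fold higher number from compound 1 to compound 2 (0.88 log units; beyond the scatter), with 5-acetylthiophen-2-yl in place of thiophen-3-yl on an aromatic carbon. Compound 3 (`O=Cc1cscc1-c1cncc(Cl)c1N1CCC2(CCNC2=O)CC1`) departs from compound 2 in that same place, with 4-formylthiophen-3-yl in place of 5-acetylthiophen-2-yl on an aromatic carbon. Among the compounds with values here, the entering group shares the thiophen-3-yl name with the group of compound 1, yet it also carries a formyl group, whose effect no measured step shows. Only part of a 7.6-fold higher number from compound 1 to compound 2 (0.88 log units; beyond the scatter) is therefore expected to be recovered, in the direction of a lower number in this assay. The expected change is a 2.2-fold lower number from compound 2 to compound 3 (0.35 log units; beyond the scatter). For compound 3 the estimated value is 650 nM, with an expected range of 200 nM to 2100 nM.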

Compound 3, concentration for 50% growth inhibition: 27100 nM
For compound 3 the middle estimate is 42-fold (1.62 log units) below the measured one; the measured number lies above the stated range.
By their numbers in this assay, from the lowest: compound 1; then compound 2; then compound 3.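

Formyl in place of hydrogen on an aromatic carbon of the thiophen-3-yl group gives a 140-fold higher number from compound 1 to compound 3 (2.15 log units; beyond the scatter) in this assay and so shows that a single small addition to this thiophene, which sits ortho to a large group, can cost far more than the earlier pair suggested. The 4-formylthiophen-3-yl group also does worse than 5-acetylthiophen-2-yl, with a 19-fold higher number from compound 2 to compound 3 (1.27 log units; beyond the scatter) in the same assay, so carrying a carbonyl on the thiophene does not by itself set the number; where it sits or what else differs between the two groups must count. Nothing measured here explains the loss.

The compounds shown leave open whether the loss belongs to the formyl group itself or to that ring carbon. A hydroxymethyl or aminomethyl group on the same carbon would separate the two.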